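Swapping a Nitrophenyl for an Aminophenyl on the Triazole

The source may hold more compounds than are shown below. What is called first, only, known or untested is meant among the compounds shown, and "the series" means these compounds.

Three measured compounds share one core. Compound 1 `CNC(=O)[C@@]12C[C@@H]1[C@@H](n1cnc3c(NCc4cccc(Cl)c4)nc(C#CCCC(=O)NCCNC(=O)CCCCC4SCC5NC(=O)NC54)nc31)[C@H](O)[C@@H]2O` carries a long flexible chain, compound 2 `CNC(=O)[C@@]12C[C@@H]1[C@@H](n1cnc3c(NCc4cccc(Cl)c4)nc(C#CCCCCc4cn(-c5cccc([N+](=O)[O-])c5)nn4)nc31)[C@H](O)[C@@H]2O` a 3-nitrophenyl on a five-membered aromatic ring, and compound 3 `CNC(=O)[C@@]12C[C@@H]1[C@@H](n1cnc3c(NCc4cccc(Cl)c4)nc(C#CCCCCc4cn(CCCCCCC(=O)NCCOCOCOCOCNC5SCC6NC(=O)NC65)nn4)nc31)[C@H](O)[C@@H]2O` a much longer chain. In an assay on CHO cells for displacement of a labelled ligand from adenosine receptor A3 (Homo sapiens), read by scintillation counting (on this read-out higher numbers stand for weaker inhibition and lower numbers for stronger inhibition), compound 1 gives 36.4 nM, compound 2 gives 10.6 nM and compound 3 gives 235 nM. Compound 2 thus has the lowest number of the three, beyond the scatter from both others. Compound 4 `CNC(=O)[C@@]12C[C@@H]1[C@@H](n1cnc3c(NCc4cccc(Cl)c4)nc(C#CCCCCc4cn(-c5ccc(N)cc5)nn4)nc31)[C@H](O)[C@@H]2O` differs from compound 2 in one place: 4-aminophenyl in place of 3-nitrophenyl on an aromatic nitrogen. Going by the values given here, no measured pair shows such a swap, so in this assay the step is expected to be small, with no clear direction, a 1.4-fold higher number from compound 2 to compound 4 (0.15 log units; within the scatter). Compound 4 is estimated at 15 nM, between 5 nM and 45 nM.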

Compound 4, inhibition constant: 87.1 nM
Beside the measured number, compound 4's estimate is 5.8-fold (0.76 log units) below it, outside the stated range (above it).
By their numbers in this assay, from the lowest: compound 2; then compound 1; then compound 4; then compound 3.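

Replacing 3-nitrophenyl with 4-aminophenyl on the aromatic nitrogen gives an 8.2-fold higher number from compound 2 to compound 4 (0.91 log units; beyond the scatter) in this assay while the six-membered carbon ring stays in place. Going by these compounds alone, this position therefore responds to what that ring carries, a point the earlier compounds could not show, as no two of them differed in one place. Nothing here accounts for the loss of inhibition.

The two names differ in both the group and its number on the ring, so the effects of each remain mixed. A plain phenyl or a carboxylic acid on that ring could help separate them.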